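This account rests on a few compounds, and the source may have more. Where it says the series, first, only, none or still open, it means among the compounds named here.

Compound 1 `CC(=O)Nc1ccc(-n2nncc2CN2C(=O)C3(C(C#N)=C(N)Oc4c3c3nc5ccccc5nc3c3ccccc43)c3ccccc32)cc1` — in an ADME assay on L02 cells (Homo sapiens) for antiproliferative activity, read by MTT assay, with a stated time of 48 h (a lower number here means a stronger inhibitor, a higher number a weaker inhibitor), compound 1 gives > 50000 nM, which is a limit of the assay and not a number.
Compound 2 `Cc1cccc(-n2nncc2CN2C(=O)C3(C(C#N)=C(N)Oc4c(N)cc5nc6ccccc6nc5c43)c3ccccc32)c1` — in this assay compound 2 gives > 50000 nM, again only a limit.
Compound 3 `N#CC1=C(N)Oc2c(N)cc3nc4ccccc4nc3c2C12C(=O)N(Cc1cnnn1-c1ccccc1Cl)c1ccccc12` — in this assay compound 3 gives > 50000 nM, likewise only a limit.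

So compound 3 stands nowhere in particular on these numbers: it sits at a limit, and the two other values shown are limits as well. Among the measured compounds shown here, no compound here has a measured inhibitory concentration at all.

Compound 4 `CCOc1ccccc1-n1nncc1CN1C(=O)C2(C(C#N)=C(N)Oc3c(N)cc4nc5ccccc5nc4c32)c2ccccc21` is the next compound. It differs from compound 3 in one place: ethoxy in place of chloro on an aromatic carbon.

For the measured compounds named here, only one measured step comes close to this change, the one from compound 2 to compound 3 a step that the two limits leave unreadable from compound 2 to compound 3. Because the limit of > 50000 nM in this assay, at which 3 of the 3 values shown sit, holds for every value shown, that step cannot be read in size or direction, and it offers no guide to what an ethoxy in place of a chloro might do. There is therefore no basis for expecting a step beyond the scatter in this assay in either direction; the most that can be said is that compound 4 is expected to sit where compound 3 sits.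

The estimate for compound 4 in this assay is 60000 nM, within a range from 20000 nM to 200000 nM, and the expected step from compound 3 to compound 4 is a step that the limit leaves unreadable from compound 3 to compound 4, most likely reported as a limit once more.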

Compound 4, half-maximal inhibitory concentration: > 50000 nM
Compound 4: a limit, no number; the forecaster's own chance of this, stated with the estimate: 85%; the middle value does not contradict the limit.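

Neither the change from compound 3 to compound 4 nor the change from compound 2 to compound 4 can be read in size or direction, because the results are limits and not numbers: the limit of > 50000 nM in this assay, at which 4 of the 4 values shown sit.
The compounds shown leave open whether any change to the group on the aromatic nitrogen would give a measured number in this assay.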